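The compounds below may be only part of what the source reports. "The series", "measured", "known", "first", "only" and "open" are said of these compounds alone.

The measured compounds, with their values in an assay on isolated protein for inhibition of cathepsin S (Homo sapiens); on this read-out higher numbers stand for weaker inhibition and lower numbers for stronger inhibition:

Compound 1, `COc1cc(C)c(NCCNC(=O)[C@H](CC(C)C)NC(=O)c2cccc(C)c2)c(C)c1`; compound 1 gives 132 nM.
Compound 2, `Cc1cccc(C(=O)N[C@@H](CC(C)C)C(=O)NCCNc2ccc(F)cc2)c1`; compound 2 gives 563 nM.
Compound 3, `COc1cccc(C(=O)N[C@@H](CCC2CCCCC2)C(=O)NCCN2CCc3cc(F)ccc32)c1`; compound 3 gives 2130 nM.

Of these three, compound 3 has the highest number and is therefore the weakest inhibitor of the set; compound 2 stands nearest to it, and compound 1 stands furthest away, with the lowest number of the three. For the measured compounds named here, only one step between neighbouring structures has been measured: a 4.3-fold higher number from compound 1 to compound 2 (0.63 log units; beyond the scatter). That step exchanges one aryl group for another on an amine nitrogen, a part of the molecule far from the change considered next.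

Compound 4, `COc1cccc(C(=O)N[C@@H](CCC2CCCCC2)C(=O)N[C@H](CN2CCc3cc(F)ccc32)[C@@H](C)O)c1`, differs from compound 3 in a single place: 1-hydroxyethyl in place of hydrogen on a saturated chain carbon bound to an amide-type nitrogen and a saturated chain carbon. Going by the values given here, no measured step touches this position, so there is nothing in the set to scale the expectation on; the step from compound 1 to compound 2 concerns a different part of the molecule. With no guide, compound 4 is expected to give about 1500 nM in this assay, within a range of 400 nM to 5000 nM. This estimate means a step of a 1.4-fold lower number from compound 3 to compound 4 (0.15 log units; within the scatter), which is expected to stay close to the usual scatter.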

Compound 4, inhibition constant: 8 nM
Beside the measured number, compound 4's estimate is 190-fold (2.27 log units) above it; the measured number lies below the stated range.
By their numbers in this assay, from the lowest: compound 4; then compound 1; then compound 2; then compound 3.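

In this assay the saturated chain carbon bound to an amide-type nitrogen and a saturated chain carbon proves to be a highly sensitive place: 1-hydroxyethyl in place of hydrogen brings a 270-fold lower number from compound 3 to compound 4 (2.43 log units; beyond the scatter) with the addition of only 3 heavy atoms. This step is far larger than the only other step available, a 4.3-fold higher number from compound 1 to compound 2 (0.63 log units; beyond the scatter) for the exchange of one aryl group for another, so among these compounds a small addition at this position counts for more than a larger exchange elsewhere in the molecule. No supporting measurement is available to explain how this gain arises.

The compounds shown leave open whether the hydroxyl of the new group is needed, which a plain ethyl at the same place would test, and whether a shorter hydroxymethyl or a 1-aminoethyl would serve as well. They also leave open how much the defined stereocentre in 1-hydroxyethyl matters, since only one arrangement of it appears here.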